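The compounds below may be only part of what the source reports. "The series", "measured", "known", "first", "only" and "open" are said of these compounds alone.

Measured in a functional assay for inhibition of nuclear factor NF-kappa-B complex (Homo sapiens); on this read-out higher numbers stand for weaker inhibition and lower numbers for stronger inhibition:
- compound 1 `COc1ccc2c(c1)OC(c1cc(OC)c(OC)c(OC)c1)C(C(=O)NC(C)(C)C)=C2` gives 28400 nM
- compound 2 `CCCC(=O)C1=Cc2ccc(OC)cc2OC1c1cc(OC)c(OC)c(OC)c1` gives 11700 nM
- compound 3 `COc1ccc2c(c1)OC(c1cc(OC)c(OC)c(OC)c1)C(/C=N/O)=C2` gives 14100 nM

Compound 3 stands second highest of the three; compound 2 is nearest and compound 1 furthest, both within the scatter. Compound 4 `CCNC(=O)C1=Cc2ccc(OC)cc2OC1c1cc(OC)c(OC)c(OC)c1` differs from compound 3 by a group of 5 heavy atoms (3 carbon, 1 nitrogen, 1 oxygen; no ring) in place of a group of 3 heavy atoms (1 carbon, 1 nitrogen, 1 oxygen; no ring), on a double-bonded ring carbon. Among the compounds with values here, the steps that bear on this are a 2.0-fold lower number from compound 1 to compound 3 (0.30 log units; within the scatter), which replaced a larger amide with the oxime, and a 1.2-fold higher number from compound 2 to compound 3 (0.08 log units; within the scatter); also a 2.4-fold lower number from compound 1 to compound 2 (0.39 log units; beyond the scatter), which shows the larger amide behind the highest number. Compound 4 carries a smaller amide than compound 1, so a number between compound 3 and compound 1 is expected, a step of a 1.3-fold higher number from compound 3 to compound 4 (0.11 log units; within the scatter) that is likely within the scatter. Compound 4 is estimated at 18000 nM, range 8000 nM to 40000 nM.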

Compound 4, half-maximal inhibitory concentration: > 50000 nM
Compound 4 was reported as a limit; the forecaster's own chance of this, stated with the estimate: 10%; middle value at least 2.7-fold (0.44 log units) from the limit.
By their numbers in this assay, from the lowest: compounds 2, 3 and 1 (each within the scatter of the next, the first and the last beyond it). At a limit, above all of these: compound 4.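

In this assay compound 4 is reported only as a limit, > 50000 nM. At this double-bonded ring carbon, the ethylcarbamoyl group gives an at least 3.5-fold higher number from compound 3 to compound 4 (0.54 log units; beyond the scatter) and, with ethylamino in place of propyl on the carbonyl carbon, an at least 4.2-fold higher number from compound 2 to compound 4 (0.63 log units; beyond the scatter), so the change is not neutral at this position. Ethyl in place of tert-butyl on the amide-type nitrogen does not lower the number, giving an at least 1.7-fold higher number from compound 1 to compound 4 (0.24 log units; that floor lies within the scatter), a floor that lies within the scatter.

From the compounds shown here alone, the true size of all three steps stays unknown. Going by these compounds, whether a carboxylic acid or a longer ketone chain at this carbon would lower the number also remains open.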